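The source may report more compounds than this note shows. Statements on the series, on what has been measured and on what is new or still open speak of the compounds shown alone.

Measured compounds:
- compound 1 `Cc1cccc2c1nc(COc1ccc(Cl)cc1)n2CCCC1CCN(CCCc2ccccc2)CC1`: 57 nM
- compound 2 `Cc1cccc2c1nc(COc1ccc(Cl)cc1)n2CCCC1CCN(CCCC(N)=O)CC1`: 88 nM

In an assay on AV12 cells for binding affinity to Neuropeptide Y receptor type 1 (Homo sapiens) (on this read-out lower numbers stand for stronger inhibition and higher numbers for weaker inhibition), compound 2 gives 88 nM, the higher of the two numbers, with compound 1 nearest at 57 nM. The step of a 1.5-fold higher number from compound 1 to compound 2 (0.19 log units; within the scatter) shows that exchanging the group at the end of this chain left the number within the scatter.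

Compound 3 `Cc1cccc2c1nc(COc1ccc(Cl)cc1)n2CCCC1CCN(CC(=O)N2CCCCC2)CC1` has not yet been measured in this assay. Its difference from compound 2 is (piperidin-1-yl)carbonyl in place of 2-carbamoylethyl on a saturated chain carbon bound to an amine nitrogen in a ring. For the measured compounds named here, no measured pair covers this exact exchange; the only step at hand, a 1.5-fold higher number from compound 1 to compound 2 (0.19 log units; within the scatter), is the one just described, and it alters the same side chain without a change beyond the scatter. On that basis no step beyond the scatter is expected, and the estimated step of a 1.1-fold lower number from compound 2 to compound 3 (0.04 log units; within the scatter) is small. The expected value for compound 3 is 80 nM, with a range from 30 nM to 250 nM.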

Compound 3, inhibition constant: 136 nM
For compound 3 the middle estimate is 1.7-fold (0.23 log units) below the measured one, within the range that was stated.
By their numbers in this assay, from the lowest: compounds 1, 2 and 3 (each within the scatter of the next, the first and the last beyond it).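

Replacing 2-carbamoylethyl with (piperidin-1-yl)carbonyl gives a 1.5-fold higher number from compound 2 to compound 3 (0.19 log units; within the scatter) in this assay and shows that this position tolerates a six-membered non-aromatic ring and the loss of the hydrogen-bond donor without leaving the scatter. Against the phenethyl group of compound 1, the same group gives a 2.4-fold higher number from compound 1 to compound 3 (0.38 log units; beyond the scatter) and is the only step here beyond the scatter, so two steps that each stay within the scatter can together exceed it. No measurement offered here accounts for these numbers.

The step to compound 3 adds the ring and changes the chain length together, and these two changes cannot be told apart here. Going by these compounds, it also remains open how an amine or a carboxylic acid at the end of this chain would read out.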